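Ring swap at the aromatic nitrogen in a weak series

The source may hold more compounds than are shown below. What is called first, only, known or untested is meant among the compounds shown, and "the series" means these compounds.

Measured in an assay on isolated protein for inhibition of protein kinase C delta type (Homo sapiens), read by TR-FRET, with a stated time of 2 h; a lower number here means a stronger inhibitor, a higher number a weaker inhibitor:
compound 1 `N#Cc1cnc(NCc2cnccc2C(F)(F)F)cc1N[C@H]1C[C@@H](O)C1` gives > 10000 nM
compound 2 `CO[C@H]1CC[C@@H](CNc2cc(NCc3cnccc3C(F)(F)F)ncc2C#N)CC1` gives 5000 nM
compound 3 `CO[C@H]1CC[C@H](CNc2cc(NCc3cnccc3C(F)(F)F)ncc2C#N)CC1` gives > 10000 nM

The value for compound 1 is a limit of this assay, not a number, as the limit of > 10000 nM in this assay, at which 2 of the 3 values shown sit, records. Compound 2 does reach a number, so the step of an at least 2.0-fold lower number from compound 1 to compound 2 (0.30 log units; that floor lies within the scatter) is read only as a floor. Compound 3 is again reported as a limit, and the step that the two limits leave unreadable from compound 1 to compound 3 cannot be read. The step of an at least 2.0-fold higher number from compound 2 to compound 3 (0.30 log units; that floor lies within the scatter) rests on (the fact that compounds 2 and 3 differ only in the configuration as drawn).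

Compound 4 `CNC(=O)[C@H]1CC[C@@H](Nc2cc(NCc3cnccc3C(F)(F)F)ncc2C#N)CC1` is not yet measured. Its change from compound 1 is 4-(methylcarbamoyl)cyclohexyl in place of 3-hydroxycyclobutyl on a nitrogen on an aromatic ring. Going by the values given here, only the step from compound 1 to compound 2 bears on a change of ring at this nitrogen, and its floor lies within the scatter; all it shows is that a six-membered non-aromatic ring of carbon only can give a number rather than a limit. No step beyond the scatter is expected in this assay. The estimate for compound 4 is 6000 nM, with a range from 1500 nM to 30000 nM. This expected step of an at least 1.6-fold lower number from compound 1 to compound 4 (0.22 log units; that floor lies within the scatter) may well again come back only as a limit.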

Compound 4, half-maximal inhibitory concentration: 1600 nM
Compound 4: middle estimate off by 3.8-fold (0.57 log units), on the high side; measured number inside the range.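

In this assay, going by these compounds alone, 4-(methylcarbamoyl)cyclohexyl on the nitrogen on the aromatic ring gives the first steps at this position that lie beyond the scatter: an at least 6.2-fold lower number from compound 1 to compound 4 (0.79 log units; beyond the scatter) and an at least 6.2-fold lower number from compound 3 to compound 4 (0.79 log units; beyond the scatter). Both are floors only, set by a limit of the assay: the limit of > 10000 nM in this assay, at which 2 of the 4 values shown sit. Within the data shown here, the only step here between two real numbers is a 3.1-fold lower number from compound 2 to compound 4 (0.49 log units; beyond the scatter), so this change at the nitrogen can now be sized rather than merely bounded.

Going by these compounds, each swap replaces the whole group, so the share of the methylcarbamoyl apart from the six-membered ring stays open. Also open, on these data alone, is whether a carboxylic acid, an amine or a longer chain in place of methylcarbamoyl on the same ring would hold or shift the number in this assay.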